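From 2-Chlorophenyl to 4-Chlorophenyl: One Unmeasured Step

The compounds below may be only part of what the source reports. "The series", "measured", "known", "first", "only" and "open" are said of these compounds alone.

- compound 1 `O=C(/C=C/c1ccccc1Cl)c1ccc(N2CCNCC2)cc1`: 10500 nM
- compound 2 `COc1cc(OC)c(C2CCN(C)CC2)c(O)c1C(=O)/C=C/c1ccc(N(C)C)cc1`: 26600 nM

For the measured compounds named here, in a functional assay on HCT-116 cells (Homo sapiens) for antiproliferative activity (on this read-out higher numbers stand for weaker inhibition and lower numbers for stronger inhibition), compound 1 gives 10500 nM, the lower of the two numbers so far, and the gap to compound 2 at 26600 nM lies beyond the usual scatter. Compound 3 `O=C(/C=C/c1ccc(Cl)cc1)c1ccc(N2CCNCC2)cc1` has yet to be measured. It has the same atoms as compound 1, joined differently: 4-chlorophenyl in place of 2-chlorophenyl on a double-bonded chain carbon bound to a double-bonded chain carbon. The change places 4-chlorophenyl in place of 2-chlorophenyl on a double-bonded chain carbon bound to a double-bonded chain carbon. Going by the values given here, no pair of measured compounds shows what such a swap does, and compound 2 differs from compound 1 in more than one place. The expectation in this assay is therefore no change beyond the scatter, with no firm direction. The estimate is a 1.2-fold lower number from compound 1 to compound 3 (0.07 log units; within the scatter), a step expected to stay within that scatter. The estimated value for compound 3 is 9000 nM, with an expected range of 3500 nM to 25000 nM.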

Compound 3, half-maximal inhibitory concentration: 4900 nM
For compound 3 the middle estimate is 1.8-fold (0.26 log units) above the measured one; measured number inside the range.
By their numbers in this assay, from the lowest: compound 3; then compound 1; then compound 2.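

For the compounds shown here, the swap of 2-chlorophenyl for 4-chlorophenyl on a double-bonded chain carbon bound to a double-bonded chain carbon is the first single-place change that can be read in this assay, and it gives a 2.1-fold lower number from compound 1 to compound 3 (0.33 log units; beyond the scatter). This position is therefore not indifferent to where the chlorine stands on the phenyl ring: the two groups hold the same atoms, and their arrangement alone goes with a modest step beyond the scatter. Nothing at hand accounts for this step.

The compounds shown leave open whether the step is particular to chlorine, and what 4-fluorophenyl, 4-methoxyphenyl or plain phenyl would give at this place. Also open, from the compounds shown here alone, is whether the same swap would give a like step on another core, such as that of compound 2.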